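This account rests on a few compounds, and the source may have more. Where it says the series, first, only, none or still open, it means among the compounds named here.

Measured so far in a functional assay on the whole organism (strain Wister albino) for inhibition, with Rattus norvegicus as the target, read by paw edema, with a stated time of 1 h, at a dose of 50 mg/kg by the intraperitoneal route; a higher number here means more inhibition at the dose given (going by the name of the read-out), a lower number less inhibition:

compound 1 `CN1C(=O)[C@@]2(c3ccccc31)N(C)C[C@@H](c1ccco1)[C@@]21Cc2ccccc2C1=O`: compound 1 gives 50.1%
compound 2 `CN1C[C@@H](c2cccs2)[C@@]2(Cc3ccccc3C2=O)[C@@]12C(=O)Nc1ccccc12`: compound 2 gives 49.9%
compound 3 `Cc1ccc([C@@H]2CN(C)[C@]3(C(=O)N(C)c4ccccc43)[C@]23Cc2ccccc2C3=O)cc1`: compound 3 gives 46.9%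

Compound 3 has the lowest of the three numbers, but its gaps to compound 2 and to compound 1 both lie within the scatter, so no order among the three can be read. Going by the values given here, the only single-point step measured, a number 3.2 percentage points lower from compound 1 to compound 3 (within the scatter), is within the scatter.

Compound 4 `CN1C(=O)[C@@]2(c3ccccc31)N(C)C[C@@H](c1cccs1)[C@@]21Cc2ccccc2C1=O` differs from compound 3 in one place: thiophen-2-yl in place of 4-methylphenyl on a saturated ring carbon. The step from compound 1 to compound 3 exchanged one aromatic group for another on the same saturated ring carbon and left the read-out unchanged beyond scatter; compound 2 carries thiophen-2-yl at that carbon, differs from compound 4 elsewhere in the core, and its value sits within scatter of compound 3. On this basis no step beyond the scatter is expected in this assay from compound 3 to compound 4; the expected step is a number 2.1 percentage points higher from compound 3 to compound 4 (within the scatter). Compound 4 is estimated at 49%, between 40% and 58%.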

Compound 4, a percentage reported as inhibition, in the whole organism at one dose (the size of the read-out at that dose, not a potency): 33%
The estimate for compound 4 lay 16 percentage points above the measured number; the measured number lies below the stated range.
By their numbers in this assay, from the lowest: compound 4; then compounds 3, 2 and 1 (each within the scatter of the next).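

In this assay, the group on the saturated ring carbon matters once the amide-type nitrogen carries methyl: thiophen-2-yl reads lower than 4-methylphenyl (a number 13.9 percentage points lower from compound 3 to compound 4 (beyond the scatter)) and lower than furan-2-yl (a number 17.1 percentage points lower from compound 1 to compound 4 (beyond the scatter)), although the exchange between those last two groups stayed within the scatter. Thiophen-2-yl does not give a low number in every setting, since methyl in place of hydrogen on the amide-type nitrogen also produces a drop (a number 16.9 percentage points lower from compound 2 to compound 4 (beyond the scatter)), so the low value appears only with this pairing among the compounds shown. Nothing available accounts for this drop. From the compounds shown here alone, whether methyl on that nitrogen lowers the read-out with furan-2-yl or 4-methylphenyl on the saturated ring carbon remains open. So does the reading with an amine or a carboxylic acid at that carbon.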